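Amide nitrogen substituents in a rat paw edema test

The source may hold more compounds than are shown below. What is called first, only, known or untested is meant among the compounds shown, and "the series" means these compounds.

Compound 1 `CCCCCCNC(=O)CC1CCc2cc(OC)c(OC)cc21`: 44.6%
Compound 2 `COc1cc2c(cc1OC)C(CC(=O)NC1CCCC1)CC2`: 43.5%
Compound 3 `COc1cc2c(cc1OC)C(CC(=O)NC1CCCCC1)CC2`: 49.3%

These three compounds share one core and differ only in the group on the amide-type nitrogen, all tested in a functional assay on the whole organism (strain Wistar) for inhibition, with Rattus norvegicus as the target, read by paw edema, with stated times of 60 min and 3 h, at a dose of 100 mg/kg by the oral route; on this read-out lower numbers stand for less inhibition and higher numbers for more inhibition at the one dose given (going by the name of the read-out). Compound 3 has the highest of the three numbers, yet the gaps a number 4.7 percentage points higher from compound 1 to compound 3 (within the scatter) and a number 5.8 percentage points higher from compound 2 to compound 3 (within the scatter) lie within the scatter, so the three cannot be told apart. Compound 4 `COc1cc2c(cc1OC)C(CC(=O)N1CCCCC1)CC2` is not yet measured; it differs from compound 3 in one place: piperidin-1-yl in place of cyclohexylamino on a carbonyl carbon. Within the data shown here, no measured step removes a hydrogen-bond donor; the steps of a number 1.1 percentage points lower from compound 1 to compound 2 (within the scatter), a number 4.7 percentage points higher from compound 1 to compound 3 (within the scatter) and a number 5.8 percentage points higher from compound 2 to compound 3 (within the scatter) only reshape the carbon group and stay within the scatter. The step of a number 4.3 percentage points lower from compound 3 to compound 4 (within the scatter) is therefore expected to be small, with a wide range. Because the steps of a number 4.7 percentage points higher from compound 1 to compound 3 (within the scatter) and a number 5.8 percentage points higher from compound 2 to compound 3 (within the scatter) are within the scatter, compound 4 is estimated at 45%, between 28% and 60%.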

Compound 4, a percentage reported as inhibition, in the whole organism at one dose (the size of the read-out at that dose, not a potency): 31.9%
Compound 4: middle estimate off by 13.1 percentage points, on the high side; the range from low to high includes it.
By their numbers in this assay, from the lowest: compound 4; then compounds 2, 1 and 3 (each within the scatter of the next).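

Reshaping the carbon group while keeping the amide hydrogen gave no readable difference, but the switch to piperidin-1-yl on the carbonyl carbon gives a number 17.4 percentage points lower from compound 3 to compound 4 (beyond the scatter) and a number 11.6 percentage points lower from compound 2 to compound 4 (beyond the scatter) and a number 12.7 percentage points lower from compound 1 to compound 4 (beyond the scatter) in this series. Among these compounds, compound 4 is the only compound here with no hydrogen-bond donor at this position, though its ring also differs from the other groups. Nothing measured here gives a reason for the lower number.

Still open, going by these compounds, is whether cyclohexylamino with a methyl on its nitrogen would give a similarly low number, which would test the missing amide hydrogen with the carbon ring kept. Also open, on these data alone, is how pyrrolidin-1-yl or morpholin-4-yl would compare with piperidin-1-yl.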